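Halogen exchange on the arylidene ring: bromo analogue

This account rests on a few compounds, and the source may have more. Where it says the series, first, only, none or still open, it means among the compounds named here.

Measured in an ADME assay on J774 cells (Mus musculus) for cytotoxicity, read by MTT assay, with a stated time of 48 h, tested at 150 ug/mL; a higher number here means a weaker effect of the compound at the concentration tested, a lower number a stronger effect:
- compound 1 `O=C(N/N=C/c1cccc(Cl)c1)c1cnccn1` gives 100%
- compound 2 `O=C(N/N=C/c1cccc(F)c1)c1cnccn1` gives 40%

Compound 2 holds the lowest of the two numbers in this assay; its nearest neighbour is compound 1, which lies higher by a step beyond the scatter. Compound 3 `O=C(N/N=C/c1cccc(Br)c1)c1cnccn1` is not yet measured; it differs from compound 2 by bromo in place of fluoro on an aromatic carbon. For the measured compounds named here, the only step that bears on this change is a number 60 percentage points lower from compound 1 to compound 2 (beyond the scatter), a large drop when chloro gave way to fluoro on the same carbon. Going by the values given here, the new change again swaps the halogen on that carbon, this time removing fluoro, so a step of comparable size in the opposite direction is expected, though no bromo compound anchors it. The estimated step is a number 45 percentage points higher from compound 2 to compound 3 (beyond the scatter), and compound 3 is expected to give about 85% in this assay, within 55% to 100%.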

Compound 3, a percentage reported as activity, at one concentration (the size of the read-out at that concentration, not a potency): 93%
For compound 3 the middle estimate is 8 percentage points below the measured one; the measured number falls inside the stated range.
By their numbers in this assay, from the lowest: compound 2; then compounds 3 and 1 (each within the scatter of the next).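

On this aromatic carbon, meta to a large group, bromo in place of fluoro gives in this assay a number 53 percentage points higher from compound 2 to compound 3 (beyond the scatter), so a second large step now leads away from fluoro, matching the one that led to it from chloro. Bromo in place of chloro gives a number 7 percentage points lower from compound 1 to compound 3 (within the scatter), so chloro and bromo cannot be told apart here, and among the three halogens shown only fluoro stands apart. Nothing at hand explains why the fluoro compound separates from the other two.

Whether fluoro would stand apart in the same way at another carbon of this ring remains open, since the compounds shown vary this one place only. Also open, on these data alone, is how a group other than a halogen, such as methoxy, an amine or a nitrile, would read on this carbon in this assay.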